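The source may hold more compounds than are shown below. What is called first, only, known or untested is meant among the compounds shown, and "the series" means these compounds.

Measured values in a functional assay on HEL cells (Homo sapiens) (a lower number here means that less compound is tolerated, a higher number that more compound is tolerated), follow
- Compound 1 `CCCCCCCCCc1cc2cn(C3CCC(CO)O3)c(=O)nc2o1` gives > 200000 nM
- Compound 2 `CCCCCCCCCCc1cc2cn(C3CCC(CO)O3)c(=O)nc2o1` gives > 200000 nM
- Compound 3 `CCCCCCCCCCCc1cc2cn(C3CCC(CO)O3)c(=O)nc2o1` gives > 200000 nM

Each of these values is a limit and not a number. Compound 3 thus stands with the rest of the series at the limit of > 200000 nM in this assay, at which 3 of the 3 values shown sit, and has no readable position of its own. Compound 4 `CCCCCCCCCCCCCCc1cc2cn(C3CCC(CO)O3)c(=O)nc2o1` differs from it by propyl in place of hydrogen on a saturated chain carbon, ten or more bonds along the chain from an aromatic carbon, that is, propyl in place of hydrogen on a saturated chain carbon. The closest measured changes are a step that the two limits leave unreadable from compound 2 to compound 3 and a step that the two limits leave unreadable from compound 1 to compound 2, while a step that the two limits leave unreadable from compound 1 to compound 3 adds no size either. With no readable size to carry forward, the expected a number no higher from compound 3 to compound 4 (the limit leaves the size open) is none beyond the scatter, in neither direction. Compound 4 is estimated at 200000 nM, within a range of 100000 nM to 400000 nM, and will probably be reported only as a limit.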

Compound 4, half-maximal cytotoxic concentration: > 200000 nM
Compound 4 gave a limit, no number; the forecaster's own chance of this, stated with the estimate: 80%; the middle value sits exactly at the limit.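

Compound 4 adds no readable step from compound 1, compound 2 or compound 3 in this assay, since every value is a limit and not a number: the limit of > 200000 nM in this assay, at which 4 of the 4 values shown sit.

The compounds shown leave open the actual half-maximal cytotoxic concentration of each compound, and whether chain length alters it at all.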